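Ethoxy in place of hydrogen on the shared core

This account rests on a few compounds, and the source may have more. Where it says the series, first, only, none or still open, it means among the compounds named here.

The series rests on two measured compounds. Compound 1 `COc1ccc(/C=C/c2cc(OC)cc(OC)c2/C=C/C(=O)c2cc3ccccc3oc2=O)cc1` carries a hydrogen at the position of interest, and in an assay on isolated protein for inhibition of Amine oxidase [flavin-containing] A (Homo sapiens), read by fluorescence, with a stated time of 15 min (on this read-out higher numbers stand for weaker inhibition and lower numbers for stronger inhibition), compound 1 gives 41700 nM. Within the data shown here, that is the only true number available, since the second value is a limit. Compound 2 `COc1ccc(/C=C/c2cc(OC)cc(OC)c2/C=C/C(=O)c2cc3cc(OC)ccc3oc2=O)cc1` bears a methoxy in place of that hydrogen on an aromatic carbon, and in this assay compound 2 gives only > 60000 nM, a limit of the assay rather than a number. The step of an at least 1.4-fold higher number from compound 1 to compound 2 (0.15 log units; that floor lies within the scatter) therefore points, if anywhere, toward weaker inhibition, resting on (the limit of > 60000 nM in this assay, at which 1 of the 2 values shown sits).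

Compound 3 `CCOc1ccc2cc(C(=O)/C=C/c3c(/C=C/c4ccc(OC)cc4)cc(OC)cc3OC)c(=O)oc2c1` is not yet measured. It differs from compound 1 by ethoxy in place of hydrogen on an aromatic carbon. Among the measured compounds shown here, the only measured step that bears on this change is an at least 1.4-fold higher number from compound 1 to compound 2 (0.15 log units; that floor lies within the scatter), where a methoxy entered the same kind of aromatic carbon; the step from compound 1 to compound 3 puts an ethoxy there instead, and a move of similar size, either none beyond the scatter or toward a higher number, is expected. Compound 3 is thus estimated at 65000 nM in this assay, within 25000 nM to 170000 nM, a step of a 1.6-fold higher number from compound 1 to compound 3 (0.19 log units; within the scatter) being expected.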

Compound 3, half-maximal inhibitory concentration: 7070 nM
The estimate for compound 3 lay 9.2-fold (0.96 log units) above the measured number; the measured number lies below the stated range.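

Ethoxy in place of hydrogen on this aromatic carbon, meta to a fused ring and para to a fused ring, gives a 5.9-fold lower number from compound 1 to compound 3 (0.77 log units; beyond the scatter), and this is the first step in the series that rests on two true numbers and lies beyond the scatter. The methoxy step, an at least 1.4-fold higher number from compound 1 to compound 2 (0.15 log units; that floor lies within the scatter), cannot be sized, since compound 2 stands at a limit of the assay and not at a number: the limit of > 60000 nM in this assay, at which 1 of the 3 values shown sits A substituent on an aromatic carbon of the shared core can therefore strengthen inhibition in this assay, which the methoxy step alone gave no sign of, and compound 2 is the one compound shown that does not follow this.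

The methoxy of compound 2 and the ethoxy of compound 3 do not stand on the same aromatic carbon, so the compounds shown do not separate what the group contributes from what its place contributes. They also leave open how a methoxy on the carbon that carries the ethoxy, a longer chain such as propoxy, or an amine there would read.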